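This account rests on a few compounds, and the source may have more. Where it says the series, first, only, none or still open, it means among the compounds named here.

Measured in a physicochemical assay for solubility, at pH 1.1; on this read-out higher numbers stand for higher solubility and lower numbers for lower solubility:
- compound 1 (`CCCN(Cc1ccc(OCCN2C(=O)CCC2=O)c(C)c1)[C@@H](CC(=O)O)c1ccc(Cl)cc1`): 3000000 nM
- compound 2 (`CCN(Cc1ccc(OCCN2C(=O)CCC2=O)c(C)c1)C(CC(=O)O)c1ccc(Cl)cc1`): 3000000 nM
- compound 3 (`Cc1cc(CN(CC2CC2)C(CC(=O)O)c2ccc(Cl)cc2)ccc1OCCN1C(=O)CCC1=O`): 3000000 nM

The three measured compounds show one and the same value at the digits reported, so compound 3 stands level with compound 1 and compound 2, with nothing to separate them.

The next compound to be measured is compound 4 (`Cc1cc(CN(CC2CC2)[C@@H](CC(=O)O)c2ccc(Cl)cc2)ccc1OCCN1C(=O)CCC1=O`). Set against compound 3, the change is this: the two compounds have the same atoms and bonds; at least one stereo element is drawn with a configuration in one of them and without one in the other: 1 of 1 stereo elements differ; a stereocentre at a saturated chain carbon is drawn without a configuration in compound 3 and S in compound 4. For the measured compounds named here, no measured step isolates a change of this kind. Going by the values given here, the only measured step, no change at the digits printed from compound 2 to compound 3 (within the scatter), is of another sort, with cyclopropyl in place of methyl on a saturated chain carbon bound to an amine nitrogen. It bears on the question only indirectly, by showing that this read-out did not move across a change in the atoms themselves, whereas compound 4 has the same atoms and bonds as compound 3. With that evidence, no step beyond the scatter is expected in this assay, in either direction. The expected step is no change at the digits printed from compound 3 to compound 4 (within the scatter). Compound 4 is therefore estimated at 3000000 nM, with an expected range from 2000000 nM to 4000000 nM.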

Compound 4, solubility: 3000000 nM
For compound 4 middle estimate and measured number coincide at the digits printed; the range from low to high includes it.
By their numbers in this assay, from the lowest: compounds 1, 2, 3 and 4 (each within the scatter of the next).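

In this assay, for the compounds shown here, the stereocentre at the saturated chain carbon is isolated for the first time, with everything else in the structure held the same, and the outcome is no change at the digits printed from compound 3 to compound 4 (within the scatter). The earlier step on the substituent at the amine nitrogen was read only between compounds drawn without a configuration, whereas the new comparison of that substituent, between two compounds drawn with one, gives no change at the digits printed from compound 1 to compound 4 (within the scatter). What this position adds to the picture is therefore limited to the drawing of the stereocentre, and the only structural difference available to compare in the first of these pairs is this one: the fact that one of compounds 3 and 4 is drawn with a defined configuration and the other without, at the place where they differ.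

The compounds shown leave open whether the R configuration at this carbon would read the same in this assay, since compound 4 is drawn S and compound 3 carries no configuration at that place. They also leave open whether a tetrazole in place of the carboxylic acid, or a longer chain on the amine nitrogen, would shift this read-out.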